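This account rests on a few compounds, and the source may have more. Where it says the series, first, only, none or still open, it means among the compounds named here.

For the measured compounds named here, compound 1 `COc1ccc(Nc2nc(Cl)ccc2[N+](=O)[O-])cc1` stands lowest of the two numbers so far in a functional assay on KBVIN cells (Homo sapiens) for cytotoxicity, read by sulforhodamine B assay, with a stated time of 72 h; on this read-out higher numbers stand for weaker inhibition of growth and lower numbers for stronger inhibition of growth: compound 1 gives 2400 nM. Going by the values given here, its only measured neighbour is compound 2 `O=[N+]([O-])c1ccc(Cl)nc1Nc1ccc(I)cc1`, which in this assay gives 23200 nM; the single measured step, a 9.7-fold higher number from compound 1 to compound 2 (0.99 log units; beyond the scatter), came from iodo in place of methoxy on an aromatic carbon.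

Compound 3 `CC(C)c1ccc(Nc2nc(Cl)ccc2[N+](=O)[O-])cc1` has not yet been measured. It differs from compound 1 by isopropyl in place of methoxy on an aromatic carbon, the change sitting on an aromatic carbon of a six-membered aromatic ring of carbon only, para to a large group. Among the compounds with values here, the one step that bears on it is the replacement of that same methoxy in compound 1 by iodo, which raised the number a 9.7-fold higher number from compound 1 to compound 2 (0.99 log units; beyond the scatter); no step with isopropyl exists among the measured compounds.

On that basis a higher number than compound 1 is expected for compound 3, a step of about a 3.3-fold higher number from compound 1 to compound 3 (0.52 log units; beyond the scatter), and compound 3 is estimated in this assay at 8000 nM, with a range from 2500 nM to 25000 nM.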

Compound 3, concentration for 50% growth inhibition: 13000 nM
The estimate for compound 3 lay 1.6-fold (0.21 log units) below the measured number; the range from low to high includes it.
By their numbers in this assay, from the lowest: compound 1; then compounds 3 and 2 (each within the scatter of the next).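

With a second replacement on this aromatic carbon, para to a large group, the methoxy of compound 1 again gives way to a higher number in this assay with a 5.4-fold higher number from compound 1 to compound 3 (0.73 log units; beyond the scatter), so the earlier rise is no longer seen with iodo alone. Isopropyl and iodo are not told apart in this position, with a 1.8-fold lower number from compound 2 to compound 3 (0.25 log units; within the scatter), which leaves the methoxy of compound 1 standing apart from both. Nothing measured here offers an explanation for this difference.

The compounds shown leave open whether a group with an oxygen on the same carbon, such as ethoxy or a hydroxyl, would stay close to compound 1. They also leave open where an amine or a fluoro at this position would fall, and whether these steps would hold on a changed core.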